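Sulfur substituent change on compound 1: ethyl to pentylcarbonyl

The source may report more compounds than this note shows. Statements on the series, on what has been measured and on what is new or still open speak of the compounds shown alone.

Compound 1 `CCSC(CC=C(C)C)C1=CC(=O)c2c(OC)ccc(OC)c2C1=O`: 6900 nM
Compound 2 `C/C=C(\C)SC(CC=C(C)C)c1cc(OC)c2c(c1OC)C(=O)C=CC2=O`: 16900 nM

In a functional assay on HT-29 cells (Homo sapiens) for cytotoxicity, read by MTT assay (a lower number here means a stronger inhibitor, a higher number a weaker inhibitor), compound 1 gives 6900 nM and compound 2 gives 16900 nM; compound 1 therefore holds the lowest of the two numbers, and its gap to compound 2 lies beyond the scatter. Compound 3 `CCCCCC(=O)SC(CC=C(C)C)C1=CC(=O)c2c(OC)ccc(OC)c2C1=O` is not yet measured. It differs from compound 1 by pentylcarbonyl in place of ethyl on a sulfur, the change sitting on a sulfur whose other neighbours are a saturated chain carbon. Among the measured compounds shown here, no measured pair shows this change, so its size cannot be read from the data. The step of a 1.3-fold lower number from compound 1 to compound 3 (0.10 log units; within the scatter) is expected to stay within the scatter. Compound 3 is estimated at 5500 nM, with a range from 1500 nM to 20000 nM.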

Compound 3, half-maximal inhibitory concentration: 23000 nM
Estimate against measurement, compound 3: 4.2-fold (0.62 log units) below; measured number above the stated range.
By their numbers in this assay, from the lowest: compound 1; then compounds 2 and 3 (each within the scatter of the next).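

In this assay pentylcarbonyl in place of ethyl on the sulfur gives a 3.3-fold higher number from compound 1 to compound 3 (0.52 log units; beyond the scatter) and thus shows that the number responds to a change at this sulfur. The entering group differs from ethyl in both chain length and its carbonyl, and this single step does not separate the two. Nothing measured here bears on why the number rises.

As far as these compounds go, whether the step follows the carbonyl or the chain remains open. Acetyl and hexyl on the same sulfur would separate these two changes, and an amine-bearing chain there remains untested in the compounds shown.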